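This account rests on a few compounds, and the source may have more. Where it says the series, first, only, none or still open, it means among the compounds named here.

Compound 1, `Nc1scc(CN2CCN(c3cccc(C(F)(F)F)c3)CC2)c1C(=O)c1ccc(Cl)cc1`: 0%
Compound 2, `Nc1scc(CN2CCN(c3ccccc3F)CC2)c1C(=O)c1ccc(Cl)cc1`: 0%
Compound 3, `Nc1scc(CN2CCN(c3cccc(F)c3F)CC2)c1C(=O)c1ccc(Cl)cc1`: 0%

Of the compounds shown here, three sharing one core have been measured in an assay on CHO cells for displacement of a labelled ligand from adenosine receptor A3 (Homo sapiens), read by scintillation counting, with a stated time of 120 min, tested at 10 uM (a lower number here means less inhibition, a higher number more inhibition at the concentration tested (going by the name of the read-out)), and each of them gives the same reading. Compound 3 stands level with compound 1 and compound 2 at the digits reported; its nearest neighbour by structure is compound 1, and the step of no change at the digits printed from compound 1 to compound 3 (within the scatter) lies within the scatter, as does the step of no change at the digits printed from compound 2 to compound 3 (within the scatter).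

Compound 4, `Nc1scc(CN2CCN(c3ccc(F)c(Cl)c3)CC2)c1C(=O)c1ccc(Cl)cc1`, has not yet been measured. It differs from compound 3 only on the ring nitrogen of the shared core: 3-chloro-4-fluorophenyl in place of 2,3-difluorophenyl on an amine nitrogen in a ring.

Within the data shown here, three measured steps bear on this change, because each of them also swaps the aryl group on that ring nitrogen or alters a substituent on it: no change at the digits printed from compound 1 to compound 2 (within the scatter), no change at the digits printed from compound 1 to compound 3 (within the scatter) and no change at the digits printed from compound 2 to compound 3 (within the scatter). None of them moved the reading beyond the scatter, whether the group was a trifluoromethyl-bearing phenyl, a fluorophenyl or a difluorophenyl. A chloro-fluoro pattern on that phenyl is not itself represented among the measured compounds, so the expectation rests on these flat steps alone.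

Compound 4 is therefore expected to show no change at the digits printed from compound 3 to compound 4 (within the scatter), a step that stays within the scatter. The estimate for compound 4 is 0%, with a range from -10% to 12%.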

Compound 4, a percentage reported as inhibition, at one concentration (the size of the read-out at that concentration, not a potency): 0%
Beside the measured number, compound 4's estimate shows no gap at the digits printed; low and high end bracket the measured number.
By their numbers in this assay, from the lowest: compounds 1, 2, 3 and 4 (each within the scatter of the next).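

In this assay, the 3-chloro-4-fluorophenyl group on the amine nitrogen in a ring puts a chlorine on that phenyl, which compound 1, compound 2 and compound 3 do not carry there, and the swap gives no change at the digits printed from compound 3 to compound 4 (within the scatter), together with no change at the digits printed from compound 2 to compound 4 (within the scatter) and no change at the digits printed from compound 1 to compound 4 (within the scatter). The flat reading at this position therefore now extends to a chlorine-bearing phenyl as well as to the trifluoromethyl, fluoro and difluoro phenyl groups, and none of the four compounds can be ranked above another. No measurement shown accounts for this flat reading.

Every compound shown keeps a substituted phenyl on that ring nitrogen, so it remains open whether a phenyl carrying a methoxy group or a carboxylic acid, or a longer chain in place of the phenyl, would give any measurable inhibition in this assay. From the compounds shown here alone, it is also open whether a change at any other place on the shared core would move the reading away from that of compound 4.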